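A few compounds are considered here, and "the series" means these few. Any claim that something is new, unique, unknown or untested is made for them only; others in the source may bear on it.

Working notes on the series. Compound 1 `C#CCSc1nc(Nc2ccc(Cl)cc2)c(C#N)c(-c2ccccc2)n1` and compound 2 `N#Cc1c(Nc2ccccc2Cl)nc(SCc2cn(Cc3ccccc3Cl)nn2)nc1-c1ccccc1` share one core and are both followed in a functional assay on MGC-803 cells (Homo sapiens) for inhibition, read by MTT assay, with a stated time of 72 h; on this read-out lower numbers stand for stronger inhibition and higher numbers for weaker inhibition. Compound 1 gives in this assay only a limit, > 128000 nM. Compound 1 thus sits at the limit of > 128000 nM in this assay, at which 1 of the 2 values shown sits. Among the compounds with values here, compound 2 gives in this assay 4640 nM, which is the only actual number obtained so far, so compound 2 stands alone as a point of reference. Compound 3 `N#Cc1c(Nc2cccc([N+](=O)[O-])c2)nc(SCc2cn(Cc3ccccc3Cl)nn2)nc1-c1ccccc1` remains to be measured; it differs from compound 2 by 3-nitrophenyl in place of 2-chlorophenyl on a nitrogen on an aromatic ring. Within the data shown here, no step between measured compounds covers this change, so its size cannot be read off the data. In this assay the expected step is a 1.3-fold higher number from compound 2 to compound 3 (0.11 log units; within the scatter), a modest shift that need not exceed the scatter. Compound 3 is accordingly estimated in this assay at 6000 nM, with a range of 1500 nM to 25000 nM.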

Compound 3, half-maximal inhibitory concentration: 43100 nM
Beside the measured number, compound 3's estimate is 7.2-fold (0.86 log units) below it, outside the stated range (above it).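

The group on a nitrogen on an aromatic ring is not a silent place in the series: in this assay the change of 2-chlorophenyl to 3-nitrophenyl gives a 9.3-fold higher number from compound 2 to compound 3 (0.97 log units; beyond the scatter), with the rest of the structure unchanged. This is the first step that can be read, and of the two groups shown, 2-chlorophenyl gives the stronger inhibition. No measured property shown here bears on the size of this step.

The change replaces the substituent and its printed ring number together, so the contribution of each cannot be separated. As far as these compounds go, whether 3-chlorophenyl, 2-nitrophenyl, or a ring carrying an amine or a carboxylic acid would read closer to compound 2 or to compound 3 remains open.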